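This account rests on a few compounds, and the source may have more. Where it says the series, first, only, none or still open, it means among the compounds named here.

Measured so far in a functional assay on cells for agonist activity at Glucose-dependent insulinotropic receptor (Homo sapiens), read by HTRF and cAMP accumulation, with a stated time of 30 min; on this read-out lower numbers stand for an effect already at smaller amounts and higher numbers for an effect only at larger amounts of compound:
compound 1 `CC(C)(C)OC(=O)N1CCC2(CC1)CC(CCCOc1ccc(S(C)(=O)=O)cc1)C2` — 14 nM
compound 2 `Cc1ccc(N2CCC3(CC2)CC(CCCOc2ccc(S(C)(=O)=O)cc2)C3)nc1` — 348 nM

For the measured compounds named here, compound 2 stands at the highest of the two numbers; the single step known, a 25-fold higher number from compound 1 to compound 2 (1.40 log units; beyond the scatter), came with 5-methylpyridin-2-yl in place of tert-butoxycarbonyl on the amine nitrogen in the ring. Compound 3 `CC(C)c1noc(N2CCC3(CC2)CC(CCCOc2ccc(S(C)(=O)=O)cc2)C3)n1` differs from compound 2 as follows: 3-isopropyl-1,2,4-oxadiazol-5-yl in place of 5-methylpyridin-2-yl on an amine nitrogen in a ring. Going by the values given here, no measured step exchanges one aromatic group for another on this nitrogen, so the size is uncertain; that earlier step shows only that this position can move the number strongly. A step of a 4.4-fold lower number from compound 2 to compound 3 (0.64 log units; beyond the scatter) is expected. Compound 3 is estimated at 80 nM, range 15 nM to 400 nM.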

Compound 3, half-maximal effective concentration: 35 nM
Estimate against measurement, compound 3: 2.3-fold (0.36 log units) above; the range from low to high includes it.
By their numbers in this assay, from the lowest: compound 1; then compound 3; then compound 2.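

In this assay, a ring on the amine nitrogen does not fix the number at the level of compound 2: the change to 3-isopropyl-1,2,4-oxadiazol-5-yl gives a 9.9-fold lower number from compound 2 to compound 3 (1.00 log units; beyond the scatter) and so recovers much of the earlier loss. The recovery is incomplete, with a 2.5-fold higher number from compound 1 to compound 3 (0.40 log units; beyond the scatter) still left against tert-butoxycarbonyl. No measurement bears on the reason for either step.

As far as these compounds go, the aromatic ring and its isopropyl group change together here, so their separate shares remain open. A 5-isopropylpyridin-2-yl or a 3-methyl-1,2,4-oxadiazol-5-yl on this nitrogen would separate them.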